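The source may report more compounds than this note shows. Statements on the series, on what has been measured and on what is new or still open speak of the compounds shown alone.

Compound 1 `O=Cc1ccc(-c2cn3ccnc3c(-c3ccc4ncn(C5CCCCC5)c4c3)n2)cc1` gives 37.8% in a functional assay on NCI-H460 cells (Homo sapiens) for inhibition, read by sulforhodamine B assay, with a stated time of 48 h, tested at 10 uM (a lower number here means less inhibition, a higher number more inhibition at the concentration tested (going by the name of the read-out)), and stands highest of the two numbers shown. Compound 2 `Fc1ccccc1-c1cn2ccnc2c(-c2ccc3ncn(C4CCCCC4)c3c2)n1` gives 8.1%; the step of a number 29.7 percentage points lower from compound 1 to compound 2 (beyond the scatter) is beyond the scatter, so loss of the 4-formylphenyl group has so far brought a modest fall.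

Compound 3 `c1csc(-c2cn3ccnc3c(-c3ccc4ncn(C5CCCCC5)c4c3)n2)c1` also leaves the 4-formylphenyl: thiophen-2-yl in place of 4-formylphenyl on an aromatic carbon. Among the compounds with values here, only the step from compound 1 to compound 2 bears on this change, and it points downward. A drop of similar size is therefore expected, a number 24.8 percentage points lower from compound 1 to compound 3 (beyond the scatter), allowing that thiophen-2-yl is not 2-fluorophenyl. Compound 3 is estimated at 13%, between 0% and 32%.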

Compound 3, a percentage reported as inhibition, at one concentration (the size of the read-out at that concentration, not a potency): 1.3%
For compound 3 the middle estimate is 11.7 percentage points above the measured one; the measured number falls inside the stated range.
By their numbers in this assay, from the lowest: compounds 3 and 2 (each within the scatter of the next); then compound 1.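

In this assay a second replacement of the 4-formylphenyl, thiophen-2-yl, gives a number 36.5 percentage points lower from compound 1 to compound 3 (beyond the scatter) so the fall is not confined to 2-fluorophenyl. The two replacing groups are not separated, with a number 6.8 percentage points lower from compound 2 to compound 3 (within the scatter) so this position does not yet rank them. No measurement on hand accounts for the higher number of compound 1.

Going by these compounds, whether that number belongs to the formyl group or to the phenyl ring carrying it stays open. Plain phenyl, or a phenyl bearing a carboxylic acid or an amine in place of the formyl, would bear on this.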